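Swapping the para ether of compound 2 for trifluoromethyl

This account rests on a few compounds, and the source may have more. Where it says the series, first, only, none or still open, it means among the compounds named here.

Measured compounds:
compound 1 `COc1ccc(/C=C/C(=O)Nc2nc(-c3c(C)cc(C)cc3C)cs2)cc1` gives 4160 nM
compound 2 `COCCOc1ccc(/C=C/C(=O)Nc2nc(-c3c(C)cc(C)cc3C)cs2)cc1` gives 1490 nM
compound 3 `COc1cc(/C=C/C(=O)Nc2nc(-c3c(C)cc(C)cc3C)cs2)cc(OC)c1OC` gives 11800 nM

In a functional assay on K562 cells (Homo sapiens) for inhibition, read by MTT assay, with a stated time of 96 h (a lower number here means a stronger inhibitor, a higher number a weaker inhibitor), compound 2 gives the lowest number of the three shown. Its nearest neighbour is compound 1, and the step of a 2.8-fold lower number from compound 1 to compound 2 (0.45 log units; beyond the scatter) is a modest gain. Compound 3 stands further away still, with the highest number of the set.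

Compound 4 `Cc1cc(C)c(-c2csc(NC(=O)/C=C/c3ccc(C(F)(F)F)cc3)n2)c(C)c1` differs from compound 2 in one place: trifluoromethyl in place of 2-methoxyethoxy on an aromatic carbon. Going by the values given here, no measured pair covers this kind of exchange. Among the compounds with values here, the only step on record, a 2.8-fold lower number from compound 1 to compound 2 (0.45 log units; beyond the scatter), concerns lengthening the ether chain on that same aromatic carbon, and its size gives a scale for what a change at this position has done so far, but not its direction for a group that is no longer an ether. Compound 3 shows that adding further methoxy groups on the ring raised the number compared with compound 1.

The expectation for compound 4 in this assay is therefore a step in the weaker direction of about a 2.7-fold higher number from compound 2 to compound 4 (0.43 log units; beyond the scatter), with wide uncertainty. Compound 4 is estimated at 4000 nM, within a range from 1200 nM to 14000 nM.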

Compound 4, half-maximal inhibitory concentration: 480 nM
Beside the measured number, compound 4's estimate is 8.3-fold (0.92 log units) above it, outside the stated range (below it).
By their numbers in this assay, from the lowest: compound 4; then compound 2; then compound 1; then compound 3.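

Going by these compounds alone, until this result, the only gain at this aromatic carbon, para to a large group, had come from lengthening an ether chain. In this assay, a group that is no ether at all goes further: trifluoromethyl in place of 2-methoxyethoxy gives a 3.1-fold lower number from compound 2 to compound 4 (0.49 log units; beyond the scatter) and, in place of methoxy, gives an 8.7-fold lower number from compound 1 to compound 4 (0.94 log units; beyond the scatter) as well, so both steps point the same way and both lie beyond the scatter. An ether oxygen at this carbon is therefore not required for the lower number, since trifluoromethyl counts no hydrogen-bond acceptors, although nothing available here says why the number falls with this exchange.

The compounds shown leave open whether this gain belongs to trifluoromethyl alone or extends to other groups on the same aromatic carbon, such as a chlorine atom, a nitrile or an amine. They also leave open whether trifluoromethyl would lower the number in the presence of the additional methoxy groups that compound 3 carries on its ring.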